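A Carboxy to Methylcarbamoyl Swap at the Assay Limit

The source may hold more compounds than are shown below. What is called first, only, known or untested is meant among the compounds shown, and "the series" means these compounds.

In a functional assay on cells (Platelet, Homo sapiens) for inhibition (a higher number here means a weaker inhibitor, a lower number a stronger inhibitor), compound 1 (`CCOC(=O)c1ccc(-c2nn(Cc3cccc(OC)c3)c3ccccc23)cc1`) gives > 10000 nM, which is a limit and not a number. Compound 2 (`CCOC(=O)c1ccc(-c2nn(-c3ccoc3)c3ccccc23)cc1`) gives > 10000 nM, again a limit. Compound 3 (`O=C(O)c1ccc(-c2nn(Cc3ccccc3)c3ccccc23)cc1`) gives > 10000 nM, also a limit, so its true position is not known.

The evidence so far is the limit of > 10000 nM in this assay, at which 3 of the 3 values shown sit. Compound 4 (`CNC(=O)c1ccc(-c2nn(Cc3ccccc3)c3ccccc23)cc1`) differs from compound 3 in one place: methylamino in place of hydroxy on a carbonyl carbon. This is methylamino in place of hydroxy on a carbonyl carbon, or carboxy to methylcarbamoyl.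

Going by the values given here, only one measured step exists, a step that the two limits leave unreadable from compound 1 to compound 2. It has no readable size and involves the group on an aromatic nitrogen, not the carbonyl carbon, so it offers no size to carry over. The data therefore set no direction for this change. The expected result is a step that the limit leaves unreadable from compound 3 to compound 4, with no clear gain expected in this assay. For compound 4 the estimated value is 15000 nM, with an expected range of 3000 nM to 60000 nM.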

Compound 4, half-maximal inhibitory concentration: > 10000 nM
Compound 4 was reported as a limit (the forecaster's own chance of this, stated with the estimate: 80%); the middle value is on the limit's open side.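

In this assay no step can be read from compound 3 to compound 4, both being reported only as limits. The compounds shown leave open how strongly any of them inhibits, and whether the carboxy to methylcarbamoyl change alters that at all: the limit of > 10000 nM in this assay, at which 4 of the 4 values shown sit.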